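Amino to methylamino: notes on compound 4

The compounds below may be only part of what the source reports. "The series", "measured", "known", "first", "only" and "open" are said of these compounds alone.

Within the data shown here, compound 3 `NC(=O)c1sc2ccccc2c1N` holds the only numeric value in an assay on isolated protein for inhibition of LIM domain kinase 1 (Homo sapiens), read by Kinase-Glo, with a stated time of 60 min (on this read-out higher numbers stand for weaker inhibition and lower numbers for stronger inhibition), giving 33000 nM. Compound 1 `NC(=O)c1sc2ccccc2c1O` reaches only the limit of > 100000 nM in this assay, at which 2 of the 3 values shown sit, in this assay, reported as > 100000 nM. Compound 2 `Nc1c(C(=O)O)sc2ccccc12` likewise returns only a limit in this assay, > 100000 nM. Both steps of an at least 3.0-fold lower number from compound 1 to compound 3 (0.48 log units; beyond the scatter) and an at least 3.0-fold lower number from compound 2 to compound 3 (0.48 log units; beyond the scatter) end at compound 3, so its amino on the aromatic carbon and its carboxamide each carry the measurable inhibition. Compound 4 `CNc1c(C(N)=O)sc2ccccc12` differs from compound 3 by methyl in place of hydrogen on a nitrogen on an aromatic ring. Among the measured compounds shown here, no measured step covers this change; the two known steps start from limits and bear on it only loosely. A step of limited size, if any, is expected, more likely toward a higher number: a 1.5-fold higher number from compound 3 to compound 4 (0.18 log units; within the scatter). Compound 4 is therefore estimated at 50000 nM, between 12000 nM and 150000 nM, with a fair chance that only a limit is reported.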

Compound 4, half-maximal inhibitory concentration: 34000 nM
Estimate against measurement, compound 4: 1.5-fold (0.17 log units) above; measured number inside the range.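

Methyl in place of hydrogen on this nitrogen on an aromatic ring gives a 1.0-fold higher number from compound 3 to compound 4 (0.01 log units; within the scatter): in this assay, the amino and methylamino forms cannot be told apart. Methylamino in place of hydroxy on an aromatic carbon gives an at least 2.9-fold lower number from compound 1 to compound 4 (0.46 log units; beyond the scatter), and the starting value for compound 1 is a limit, so this step has no fixed size: the limit of > 100000 nM in this assay, at which 2 of the 4 values shown sit.

The compounds shown leave open whether an ethyl group, a longer chain or dimethylamino at this nitrogen would read like methylamino. They also leave open whether methyl on the carboxamide nitrogen would be met in the same way.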